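This account rests on a few compounds, and the source may have more. Where it says the series, first, only, none or still open, it means among the compounds named here.

Compound 1 `C[C@@H](Cn1ccc(-c2ccc(C#N)c(Cl)c2)n1)Nc1ccccn1`: "not determined" (no result reported)
Compound 2 `C[C@@H](Cn1ccc(-c2ccc(C#N)c(Cl)c2)n1)Nc1ccncc1`: 9900 nM

Among the compounds with values here, in a functional assay on VCaP cells (Homo sapiens) for antiproliferative activity, read by CCK-8 assay, with a stated time of 6 days (on this read-out higher numbers stand for weaker inhibition and lower numbers for stronger inhibition), compound 2 holds the only number, 9900 nM, so it cannot yet be ranked against another compound. Compound 3 `C[C@@H](Cn1ccc(-c2ccc(C#N)c(Cl)c2)n1)Nc1ncnc2nc[nH]c12` keeps the shared core but gives up the pyridin-4-yl on the amine nitrogen for a larger two-ring group: a group of 9 heavy atoms (5 carbon, 4 nitrogen; one five-membered aromatic ring with 2 hetero atoms, one six-membered aromatic ring with 2 hetero atoms) in place of a group of 6 heavy atoms (5 carbon, 1 nitrogen; one six-membered aromatic ring with 1 hetero atom), on an amine nitrogen. Within the data shown here, no measured step guides this change, so only a moderate gain in this assay is expected, and a result within the usual scatter would not surprise. The estimate amounts to an expected 2.5-fold lower number from compound 2 to compound 3 (0.39 log units; beyond the scatter). Compound 3 is estimated at 4000 nM, with a likely range of 700 nM to 20000 nM.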

Compound 3, half-maximal inhibitory concentration: 640 nM
Beside the measured number, compound 3's estimate is 6.3-fold (0.80 log units) above it; the measured number lies below the stated range.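

At the amine nitrogen, the group carried there strongly affects the result in this assay: exchanging pyridin-4-yl for the larger two-ring group gives a 15-fold lower number from compound 2 to compound 3 (1.19 log units; beyond the scatter). Within the data shown here, this is the first readable comparison at this position, since compound 1 has no number to compare. No available evidence explains this step.

One change cannot show whether the gain needs both rings or the added nitrogens. As far as these compounds go, an imidazole or an indole on the same amine nitrogen would separate these possibilities, and the shared core remains untested by any readable step.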